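Moving the carboxylic acid around the distal phenyl ring

The compounds below may be only part of what the source reports. "The series", "measured", "known", "first", "only" and "open" are said of these compounds alone.

Compound 3 `Cc1c(OCCCCOc2ccccc2C(=O)O)ccc(C(=O)CC2CCCC2)c1O` gives 335 nM in an assay on HEK293 cells for positive allosteric modulation of metabotropic glutamate receptor 2 (Rattus norvegicus), read by thallium flux, with a stated time of 2.5 min; on this read-out higher numbers stand for an effect only at larger amounts of compound and lower numbers for an effect already at smaller amounts. Among the three compounds measured so far it holds the second highest number: compound 1 `Cc1c(OCCCCOc2ccc(C(=O)O)cc2)ccc(C(=O)CC2CCCC2)c1O` gives 824 nM, and compound 2 `Cc1c(OCCCCOCOc2ccc(C(=O)O)cc2)ccc(C(=O)CC2CCCC2)c1O` gives 228 nM. The step of a 2.5-fold lower number from compound 1 to compound 3 (0.39 log units; beyond the scatter) lies beyond the scatter, whereas the step of a 1.5-fold higher number from compound 2 to compound 3 (0.17 log units; within the scatter) lies within it, so compound 2 and compound 3 cannot be told apart on these numbers. Compound 4 `Cc1c(OCCCCOc2cccc(C(=O)O)c2)ccc(C(=O)CC2CCCC2)c1O` has not yet been measured. It differs from compound 3 in one place: 3-carboxyphenyl in place of 2-carboxyphenyl on an oxygen on a saturated carbon. Going by the values given here, only one measured step bears directly on this change, the step of a 2.5-fold lower number from compound 1 to compound 3 (0.39 log units; beyond the scatter), in which 2-carboxyphenyl replaced 4-carboxyphenyl at the same oxygen. The step of a 3.6-fold lower number from compound 1 to compound 2 (0.56 log units; beyond the scatter) concerns a different replacement, (4-carboxyphenoxy)methyl for 4-carboxyphenyl, and helps less. Since 3-carboxyphenyl is a third pattern that neither compound 1 nor compound 3 shows, the author expects compound 4 to land close to the span set by those two, which amounts to a step of a 1.5-fold higher number from compound 3 to compound 4 (0.17 log units; within the scatter) in this assay, expected to be modest at most. The estimate for compound 4 in this assay is 500 nM, with a range from 200 nM to 1300 nM.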

Compound 4, half-maximal effective concentration: 451 nM
Compound 4: the middle estimate sits 1.1-fold (0.04 log units) above what was measured, and the stated range covers the measured number.
By their numbers in this assay, from the lowest: compounds 2, 3, 4 and 1 (each within the scatter of the next, the first and the last beyond it).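

In this assay the 3-carboxyphenyl group on this oxygen cannot be told apart from any of the three earlier groups (the steps read a 1.3-fold higher number from compound 3 to compound 4 (0.13 log units; within the scatter) and a 2.0-fold higher number from compound 2 to compound 4 (0.30 log units; within the scatter) and a 1.8-fold lower number from compound 1 to compound 4 (0.26 log units; within the scatter)). The earlier compounds had shown a separation between the 4-carboxyphenyl and 2-carboxyphenyl groups (a 2.5-fold lower number from compound 1 to compound 3 (0.39 log units; beyond the scatter)), and the 3-carboxyphenyl group does not form a distinct level of its own, since it lies within the scatter of both. Among these three carboxyphenyl groups, any sensitivity of this place to the change therefore rests on that single step, and compound 4 does not extend it into a graded series.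

Open, from the compounds shown here alone, is whether the carboxylic acid is needed at all, since all four compounds carry one: a methyl ester, an amide, a tetrazole or a plain phenyl ring could be set in its place, and a shorter or longer chain could be paired with the 3-carboxyphenyl group. Also open, with nothing at hand to settle it, is why the 4-carboxyphenyl group stands apart from the 2-carboxyphenyl group while the 3-carboxyphenyl group stands apart from neither.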